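A Cyano Group Added to a Weak Fatty-Acid Receptor Agonist

This account rests on a few compounds, and the source may have more. Where it says the series, first, only, none or still open, it means among the compounds named here.

Of the compounds shown here, three sharing one core have been tested in a functional assay on cells for agonist activity at Free fatty acid receptor 1 (Mus musculus), read by FLIPR and calcium flux, with a stated time of 5 min; a higher number here means that more compound is needed for the effect, a lower number that less compound is needed. Compound 1 `Cc1nn(-c2ccccn2)c2cc(-c3ccc(CC(C)(C)C(=O)O)cc3)ccc12` reaches only a limit of the assay, > 100000 nM. Compound 2 `Cc1nn(-c2ccccn2)c2cc(-c3cccc(CCC(=O)O)c3)ccc12` likewise reaches only the limit > 100000 nM. Among the compounds with values here, compound 3 `O=C(O)CCc1ccc(-c2ccc3cnn(-c4ccccn4)c3c2)cc1` is the one compound with a number, 4500 nM, and so stands alone among the values shown, while the two others sit at the limit of > 100000 nM in this assay, at which 2 of the 3 values shown sit. Compound 4 `N#Cc1nn(-c2ccccn2)c2cc(-c3ccc(CCC(=O)O)cc3)ccc12` differs from compound 3 by cyano in place of hydrogen on an aromatic carbon, in words cyano in place of hydrogen on an aromatic carbon. Within the data shown here, no measured step involves such a change, and the direction is open. A small gain is expected from compound 3 to compound 4, a 1.5-fold lower number from compound 3 to compound 4 (0.18 log units; within the scatter), within the scatter of this assay. Compound 4 is therefore expected to give 3000 nM, between 600 nM and 15000 nM.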

Compound 4, half-maximal effective concentration: 2000 nM
Estimate against measurement, compound 4: 1.5-fold (0.18 log units) above; the measured number falls inside the stated range.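

In this assay, the step at this aromatic carbon of the five-membered ring is a 2.3-fold lower number from compound 3 to compound 4 (0.35 log units; beyond the scatter), modest but beyond the scatter. Within the data shown here, it is the first measured change at this position, and it shows that a cyano group there is tolerated and brings a small gain. Nothing measured here explains that gain.

On these data alone, whether a chlorine atom, an amide or a trifluoromethyl group on this same carbon would give a lower number remains open. So does whether a longer chain ending in the carboxylic acid would keep the gain.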